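Shortening the nitrogen-bound chain: compound 3 to compound 4

This account rests on a few compounds, and the source may have more. Where it says the series, first, only, none or still open, it means among the compounds named here.

Compound 1 `CCCC(C)n1c(CC)nc2c(-c3ccc(OC)nc3C(F)(F)F)ccnc21` gives 0.6 nM in an assay for binding affinity to Corticotropin releasing factor receptor (Rattus norvegicus); on this read-out lower numbers stand for stronger inhibition and higher numbers for weaker inhibition; compound 2 `CCc1nc2c(-c3ccc(OC)nc3C(F)(F)F)ccnc2n1C(CC)CCOC` gives 1.6 nM, and compound 3 `CCCC(C)n1c(CC)nc2c(-c3ccc(OC)nc3C)ccnc21` gives 1.1 nM. Compound 3 holds the second highest of the three numbers, within the scatter of both others. Compound 4 `CCc1nc2c(-c3ccc(OC)nc3C)ccnc2n1C(C)CC` differs from compound 3 by hydrogen in place of methyl on a saturated chain carbon, three bonds along the chain from an aromatic nitrogen. For the measured compounds named here, only one measured step touches this chain: a 2.7-fold higher number from compound 1 to compound 2 (0.43 log units; beyond the scatter), a different alteration of the same substituent on the aromatic nitrogen. Nothing measured removes a methyl from it. A modest change of similar size, or none beyond the scatter, is therefore expected in this assay, probably toward a higher number. Compound 4 is estimated at 2 nM, between 0.8 nM and 5 nM, a step of a 1.8-fold higher number from compound 3 to compound 4 (0.26 log units; within the scatter).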

Compound 4, inhibition constant: 9.2 nM
For compound 4 the middle estimate is 4.6-fold (0.66 log units) below the measured one; the whole stated range lies below it.
By their numbers in this assay, from the lowest: compounds 1, 3 and 2 (each within the scatter of the next, the first and the last beyond it); then compound 4.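

In this assay, hydrogen in place of methyl on this saturated chain carbon gives an 8.4-fold higher number from compound 3 to compound 4 (0.92 log units; beyond the scatter), so going from 1-methylbutyl to sec-butyl on the aromatic nitrogen is a change beyond the scatter. This is the first step shown that shortens the chain, and the methyl three bonds along it is not dispensable in this series. Nothing available accounts for the loss.

On these data alone, whether a longer chain such as 1-methylpentyl would match compound 3 stays open. Also open, as far as these compounds go, is whether the same shortening has a similar effect with trifluoromethyl in place of methyl on the aromatic carbon.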